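The source may hold more compounds than are shown below. What is called first, only, known or untested is meant among the compounds shown, and "the series" means these compounds.

Going by the values given here, in a functional assay on CCRF-CEM cells (Homo sapiens) for inhibition, read by cell counting, with a stated time of 96 h (a lower number here means a stronger inhibitor, a higher number a weaker inhibitor), compound 1, `COc1ccc(N(C)c2nc(C)nc3c2nc(C)n3C)cc1`, gives 6200 nM, the only actual number among the three measured compounds. Compound 2, `COc1ccc(Nc2nc(C)nc3c2nc(C)n3C)cc1`, reads > 250000 nM, which is a limit of the assay and not a number. Compound 3, `COc1ccc(N(C)c2ncnc3c2nc(C)n3C)cc1`, reads > 250000 nM, again a limit. Hydrogen in place of methyl on a nitrogen on an aromatic ring gave an at least 40-fold higher number from compound 1 to compound 2 (1.60 log units; beyond the scatter). Hydrogen in place of methyl on an aromatic carbon gave an at least 40-fold higher number from compound 1 to compound 3 (1.60 log units; beyond the scatter). Going by these compounds, both steps are large, and the true size of each remains open.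

Compound 4, `COc1ccc(N(C)c2nc(C)nc3[nH]c(C)nc23)cc1`, makes a third such change: hydrogen in place of methyl on an aromatic nitrogen. Neither measured step was made at this place, so they serve only as the closest guides. Since both removed a methyl and both ended at the limit of this assay, a large upward step is expected here too, and the assay may report only a limit. The expected step is a 9.7-fold higher number from compound 1 to compound 4 (0.99 log units; beyond the scatter). The estimate for compound 4 is 60000 nM, with an expected range from 10000 nM to 250000 nM.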

Compound 4, half-maximal inhibitory concentration: 23000 nM
Compound 4: middle estimate off by 2.6-fold (0.42 log units), on the high side, and the stated range covers the measured number.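

Taking the methyl off the aromatic nitrogen of the five-membered aromatic ring is the first of these removals whose size can be read: in this assay it is a 3.7-fold higher number from compound 1 to compound 4 (0.57 log units; beyond the scatter), so the change costs potency but leaves a measurable number. Compound 2 and compound 3, each with a different methyl removed, give only a limit of the assay and no number: the limit of > 250000 nM in this assay, at which 2 of the 4 values shown sit. The three methyl groups of compound 1 therefore do not all behave alike here, although the methyl on this ring nitrogen still matters, since its step lies beyond the scatter.

Going by these compounds, the steps to compound 2 and compound 3 cannot be read, so how much larger they are than this one stays open. Also open, on these data alone, is what an ethyl group, a longer chain or a chain bearing an amine would do on this ring nitrogen.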